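The compounds below may be only part of what the source reports. "The series", "measured", "known", "first", "only" and "open" are said of these compounds alone.

Measured so far in a physicochemical assay for lipophilicity, using the shake flask method, in phosphate buffer, measured as octanol-water partition, with a stated time of 30 min, at pH 7.4; a lower number here means a more polar compound, a higher number a more lipophilic compound:
- Compound 1 `Cc1ncccc1-c1cnc(NCc2c(F)ccc3c2CCO3)c2nn(CC#N)c(=O)n12`: 2.2
- Compound 2 `CN(c1ncco1)c1cnc(NCc2c(F)ccc3c2CCO3)n2cnnc12`: 2.1
- Compound 3 `Cc1ncccc1-c1cnc(NCc2c(F)ccc3c2CCO3)c2n[nH]c(=O)n12`: 2.5

In this assay compound 2 gives 2.1. That is within the scatter of compound 1 at 2.2, while compound 3 at 2.5 lies higher than compound 2, beyond the scatter.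

The next compound to follow is compound 4 `CC1(C)CC(=O)N(c2cnc(NCc3c(F)ccc4c3CCO4)n3cnnc23)C1`, which differs from compound 2 in one place. It carries 4,4-dimethyl-2-oxopyrrolidin-1-yl in place of methyl(1,3-oxazol-2-yl)amino on an aromatic carbon. The swap is large, since a five-membered aromatic ring leaves and a five-membered non-aromatic ring enters.

Among the measured compounds shown here, only one measured step exists for comparison. Hydrogen in place of cyanomethyl on an aromatic nitrogen gives a number 0.30 log units higher from compound 1 to compound 3 (within the scatter). That step involves neither group and sits at another place, so it offers only a loose guide. For the measured compounds named here, no measured step shows what this particular swap does, and the range has to stay wide.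

The expected change is small and is not expected to go beyond the scatter, with an estimated a number 0.20 log units higher from compound 2 to compound 4 (within the scatter). For compound 4 the estimated value is 2.3, with an expected range from 1.8 to 2.8.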

Compound 4, distribution coefficient: 2
The estimate for compound 4 lay 0.30 log units above the measured number; measured number inside the range.
By their numbers in this assay, from the lowest: compounds 4, 2, 1 and 3 (each within the scatter of the next, the first and the last beyond it).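

Putting 4,4-dimethyl-2-oxopyrrolidin-1-yl in place of methyl(1,3-oxazol-2-yl)amino on the aromatic carbon gives, in this assay, a number 0.10 log units lower from compound 2 to compound 4 (within the scatter). This is the only step shown at this position, and it shows that a large exchange need not move the number beyond the scatter: a five-membered aromatic ring with 2 hetero atoms leaves, a five-membered non-aromatic ring with 1 hetero atom enters, and the group's count of hydrogen-bond acceptors goes from 3 to 1. Nothing available explains why these two different groups give numbers within the scatter of each other.

Going by these compounds, it remains open whether a group of another kind on this aromatic carbon, such as a simple amine or a carboxylic acid, would give a number beyond the scatter of compound 2. Also open, on these data alone, is whether the plain 2-oxopyrrolidin-1-yl ring, without its two methyl groups, would give a number within the scatter of compound 4, which would show whether those methyl groups matter at this place.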